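The source may report more compounds than this note shows. Statements on the series, on what has been measured and on what is new or still open speak of the compounds shown alone.

Going by the values given here, only two compounds have been measured here, so any forecast rests on little. In a functional assay on NCI-H460 cells (Homo sapiens) for cytotoxicity, read by MTT assay, with a stated time of 68 h (a higher number here means a weaker inhibitor, a lower number a stronger inhibitor), compound 1 (`Nc1cccc(-c2cccc(NC(=O)C(Cl)Cl)c2)c1`) gives > 50000 nM as its reading, and this is a limit of the assay and not a number. In this assay compound 2 (`Cc1ccccc1-c1cccc(NC(=O)C(Cl)Cl)c1`), which carries no amino group, gives 31600 nM as a true number. Still unmeasured is compound 3 (`O=C(Nc1cccc(-c2cccc(Cl)c2)c1)C(Cl)Cl`), which has chloro in place of amino on an aromatic carbon, meta to a large group (chloro in place of amino on an aromatic carbon). Among the compounds with values here, no measured pair shows this exact change on its own, so the best guide is compound 2 at 31600 nM in the same test. Going by that single value, compound 3 is also expected to give a real number, though a weak one. In this assay the expected change is an at least 2.0-fold lower number from compound 1 to compound 3 (0.30 log units; that floor lies within the scatter) toward a lower number and a stronger inhibitor, and its true size stays uncertain while compound 1 has only a limit. The estimated value for compound 3 is 25000 nM with an expected range from 10000 nM to 50000 nM across repeated measurements.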

Compound 3, half-maximal inhibitory concentration: > 50000 nM
Compound 3 was reported as a limit; the forecaster's own chance of this, stated with the estimate: 20%; at least 2.0-fold (0.30 log units) between middle value and limit.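

Compound 1 and compound 3 both stand as limits and not as numbers in this assay, so the step from one to the other cannot be read: the limit of > 50000 nM in this assay, at which 2 of the 3 values shown sit. The compounds shown leave open how far chloro in place of amino shifts the reading, and what true value either compound would give.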